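This account rests on a few compounds, and the source may have more. Where it says the series, first, only, none or still open, it means among the compounds named here.

Compound 2 `Oc1ccccc1-c1cc(-c2ccccc2O)nc(-c2ccccc2O)c1` gives the lowest of the two numbers measured in a functional assay on HCT-15 cells (Homo sapiens) for cytotoxicity, read by CCK-8 assay, with a stated time of 4 days; on this read-out lower numbers stand for stronger inhibition and higher numbers for weaker inhibition: compound 2 gives 2180 nM, while compound 1 `Oc1cccc(-c2cc(-c3ccccc3O)nc(-c3ccccc3O)c2)c1` gives 5020 nM. Within the data shown here, the one measured step, a 2.3-fold lower number from compound 1 to compound 2 (0.36 log units; beyond the scatter), moved the hydroxyl on one of the hydroxyphenyl groups. Compound 3 `Oc1ccc(-c2cc(-c3ccccc3O)nc(-c3ccccc3O)c2)cc1` moves that hydroxyl again: 4-hydroxyphenyl in place of 2-hydroxyphenyl on an aromatic carbon. Among the measured compounds shown here, because the only comparable step, a 2.3-fold lower number from compound 1 to compound 2 (0.36 log units; beyond the scatter), was modest and the hydroxyl again changes place on the same group, a step of similar size is expected, most likely back toward a higher number, so compound 3 is expected at 4000 nM, between 1500 nM and 12000 nM, meaning a 1.8-fold higher number from compound 2 to compound 3 (0.26 log units; within the scatter).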

Compound 3, half-maximal inhibitory concentration: > 50000 nM
Compound 3 ended at the assay's limit (the forecaster's own chance of this, stated with the estimate: 5%); at least 12-fold (1.09 log units) between middle value and limit.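

Where the hydroxyl sits on this group, opposite the ring nitrogen, matters far more than the earlier pair showed: with the same atoms joined differently, moving it to the 4-hydroxyphenyl arrangement gives an at least 22-fold higher number from compound 2 to compound 3 (1.36 log units; beyond the scatter), and likewise an at least 9.9-fold higher number from compound 1 to compound 3 (0.99 log units; beyond the scatter). Compound 3 gives > 50000 nM, which is a limit of the assay and not a number. Of these three arrangements, only 4-hydroxyphenyl leaves the cytotoxicity beyond the measured range.

On these data alone, how far compound 3 lies past that limit remains open. So does whether an amine in place of the hydroxyl on the 4-hydroxyphenyl group would bring the number back down.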